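The compounds below may be only part of what the source reports. "The series", "measured", "known", "first", "only" and "open" are said of these compounds alone.

Among the three compounds measured in an ADME assay on Vero cells (Chlorocebus sabaeus) for cytotoxicity, read by resazurin assay, with a stated time of 72 h (a lower number here means a stronger inhibitor, a higher number a weaker inhibitor), compound 3 `O=C(CCN1CCN(c2ccc(F)cc2)CC1)c1ccc(C(F)(F)F)cc1` has the lowest number, 28500 nM, while compound 1 `COc1ccc(C(=O)CCN2CCN(c3ccc(C(F)(F)F)cc3)CC2)cc1OC` gives 243000 nM. Compound 4 `O=C(CCN1CCN(c2ccc(C(F)(F)F)cc2)CC1)c1ccc(C(F)(F)F)cc1` differs from compound 3 by one change, trifluoromethyl in place of fluoro on an aromatic carbon, so 4-fluorophenyl becomes 4-(trifluoromethyl)phenyl.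

Within the data shown here, no measured pair isolates this change. Among the measured compounds shown here, the only measured step, a 3.6-fold lower number from compound 1 to compound 2 (0.56 log units; beyond the scatter), concerns a different place, the group on the carbonyl carbon, so it shows only that one swap in these compounds can move the number noticeably. A weak hint comes from compound 2 `O=C(CCN1CCN(c2ccc(C(F)(F)F)cc2)CC1)c1ccc(F)c(Br)c1`, which gives 66800 nM and already carries 4-(trifluoromethyl)phenyl where compound 3 has 4-fluorophenyl, although the two also differ on the carbonyl side.

A small move toward a higher number is therefore expected, a 1.6-fold higher number from compound 3 to compound 4 (0.20 log units; within the scatter). The estimate for compound 4 is 45000 nM, with an expected range from 18000 nM to 110000 nM.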

Compound 4, half-maximal inhibitory concentration: 49200 nM
Beside the measured number, compound 4's estimate is 1.1-fold (0.04 log units) below it; measured number inside the range.
By their numbers in this assay, from the lowest: compounds 3, 4 and 2 (each within the scatter of the next, the first and the last beyond it); then compound 1.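

In this assay, the fluoro to trifluoromethyl swap is now seen on its own, with the rest of the molecule held constant, and it gives a 1.7-fold higher number from compound 3 to compound 4 (0.24 log units; within the scatter). At this position, then, the larger trifluoromethyl group does not separate compound 4 from compound 3 beyond the usual variation between repeats. Compound 4 also allows two comparisons at the carbonyl end: a 1.4-fold lower number from compound 2 to compound 4 (0.13 log units; within the scatter) does not separate those two groups, whereas a 4.9-fold lower number from compound 1 to compound 4 (0.69 log units; beyond the scatter) shows a real difference from the 3,4-dimethoxyphenyl group.

No supporting measurement bears on what lies behind these numbers. With only fluoro and trifluoromethyl shown at this position, it remains open how a nitrile, an amine or a carboxylic acid would read there.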